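The compounds below may be only part of what the source reports. "The series", "measured", "known", "first", "only" and "open" are said of these compounds alone.

In a physicochemical assay for solubility (on this read-out higher numbers stand for higher solubility and lower numbers for lower solubility), three compounds have been measured. Compound 1 `Cn1nccc1-c1cc(C(F)(F)F)ccc1[C@H]1CCOc2cc(S(=O)(=O)Nc3cccc(F)n3)ccc21` gives 27000 nM and compound 2 `O=S(=O)(Nc1nccs1)c1ccc2c(c1)OCC[C@@H]2c1ccc(C(F)(F)F)cc1-c1ccc(F)cc1` gives 39000 nM, two values that lie within the usual scatter of each other. Compound 3 `O=S(=O)(Nc1nccs1)c1ccc2c(c1)OCC[C@H]2c1ccc(C(F)(F)F)cc1-c1ccc(F)cc1` gives 147000 nM, which stands clear of compound 2. The next compound changes compound 2 in one place. Compound 4 `O=C1COCCN1c1cc(C(F)(F)F)ccc1[C@H]1CCOc2cc(S(=O)(=O)Nc3nccs3)ccc21` arises through (3-oxomorpholin-4-yl in place of 4-fluorophenyl on an aromatic carbon), so that 3-oxomorpholin-4-yl takes the place of 4-fluorophenyl on an aromatic carbon, ortho to a large group and meta to a trifluoromethyl group.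

Among the measured compounds shown here, only one measured step bears on this, and only indirectly: a 3.8-fold higher number from compound 2 to compound 3 (0.58 log units; beyond the scatter). That step is tied to the fact that compounds 2 and 3 differ only in the configuration as drawn, so it does not test any exchange of groups. It serves only as a gauge of how far this assay has moved within this small set. For the measured compounds named here, no measured pair tests the new group, so the direction is a judgement from the structural change alone: an all-carbon aromatic ring gives way to a non-aromatic ring with 2 hetero atoms. A rise of modest size is expected, comparable to a 3.8-fold higher number from compound 2 to compound 3 (0.58 log units; beyond the scatter), though a result within the scatter would not surprise. The expected change is a 2.6-fold higher number from compound 2 to compound 4 (0.41 log units; beyond the scatter). For compound 4 the estimated value is 100000 nM, with an expected range from 30000 nM to 330000 nM.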

Compound 4, solubility: 695000 nM
For compound 4 the middle estimate is 7.0-fold (0.84 log units) below the measured one; the whole stated range lies below it.
By their numbers in this assay, from the lowest: compounds 1 and 2 (each within the scatter of the next); then compound 3; then compound 4.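

In this assay, the position on the aromatic carbon ortho to a large group and meta to a trifluoromethyl group proves highly responsive: 3-oxomorpholin-4-yl in place of 4-fluorophenyl gives an 18-fold higher number from compound 2 to compound 4 (1.25 log units; beyond the scatter). Among the compounds shown here, this large step exceeds the modest one seen for configuration alone, a 3.8-fold higher number from compound 2 to compound 3 (0.58 log units; beyond the scatter), so within this small set a change of group at this place moves the read-out further than the one stereocentre change does. The exchange keeps the heavy-atom count of the group the same while replacing an all-carbon aromatic ring, with no hydrogen-bond acceptors, by a non-aromatic ring with 2 hetero atoms, a double bond outside aromatic rings and 2 hydrogen-bond acceptors, and nothing measured here gives a reason for the size of the rise.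

The compounds shown leave open which of these differences accounts for the step, since the ring carbonyl, the ring oxygen and the loss of the aromatic ring all change together. A morpholin-4-yl group without the carbonyl, a piperidin-2-one ring or a pyridine ring at the same place would begin to separate them, and whether the rise carries over to the opposite configuration also remains unresolved.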